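Geometry swap at the exocyclic double bond of compound 3

This account rests on a few compounds, and the source may have more. Where it says the series, first, only, none or still open, it means among the compounds named here.

Three compounds have numbers in a physicochemical assay for lipophilicity; on this read-out lower numbers stand for lower lipophilicity and higher numbers for higher lipophilicity. Compound 1 `CC(C)CC(=O)OC[C@H](CO)OC(=O)C=C(C(C)C)C(C)C` gives 3.9. Compound 2 `CC(C)=C1CC(CO)(COC(=O)CC(C(C)C)C(C)C)OC1=O` gives 3.2. Compound 3 `CC(C)C/C=C1/CC(CO)(COC(=O)CC(C(C)C)C(C)C)OC1=O` gives 4.1, which sits alongside compound 1 within the scatter and above compound 2 beyond it. Compound 4 `CC(C)C/C=C1\CC(CO)(COC(=O)CC(C(C)C)C(C)C)OC1=O` is still to be measured. It differs from compound 3 as follows: the two compounds have the same atoms and bonds; at least one stereo element is drawn with a configuration in one of them and without one in the other: 1 of 2 stereo elements differ; a double bond is drawn Z in compound 3 and E in compound 4. Among the measured compounds shown here, no measured pair in the set separates by a single change, so no reference step exists for this kind of change. With the same atoms and bonds retained, no step beyond the scatter in this assay is expected in either direction. The expected step from compound 3 to compound 4 is no change at the digits printed from compound 3 to compound 4 (within the scatter). Compound 4 is estimated at 4.1, within 3.7 to 4.5.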

Compound 4, partition coefficient: 4.1
The estimate for compound 4 equals the measured number at the digits printed, and the stated range covers the measured number.
By their numbers in this assay, from the lowest: compound 2; then compounds 1, 3 and 4 (each within the scatter of the next).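

In this assay, among the compounds shown here, the swap from Z to E at the double bond gives the first reading of a single change: no change at the digits printed from compound 3 to compound 4 (within the scatter). For the compounds shown here, the earlier compounds offered no pair differing in one place, so this is the only reference step available, and it shows that this geometry swap leaves the read-out unmoved. One caveat applies to reading it as a clean comparison of two geometries: the fact that one of compounds 3 and 4 is drawn with a defined configuration and the other without, at the place where they differ.

As far as these compounds go, whether the same swap stays within the scatter when the shared core carries an amine or a carboxylic acid remains open. A longer chain at the double bond is equally untested in the compounds shown.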